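The source may report more compounds than this note shows. Statements on the series, on what has been measured and on what is new or still open speak of the compounds shown alone.

Measured so far in an ADME assay on Caco-2 cells (Homo sapiens) for permeability, in the apical to basolateral direction; on this read-out lower numbers stand for lower permeability and higher numbers for higher permeability:
- compound 1 `O=c1ncn(Cc2c(F)cc(F)cc2F)c2ccc(Oc3ccccc3C(F)(F)F)cc12`: 9.2 10^-6 cm/s
- compound 2 `NC(=O)c1cccc(Oc2ccc3c(c2)c(=O)ncn3Cc2c(F)cc(F)cc2F)c1C(F)(F)F`: 1.9 10^-6 cm/s
- compound 3 `O=C(Nc1ccccc1)c1cccc(Oc2ccc3c(c2)c(=O)ncn3Cc2c(F)cc(F)cc2F)c1C(F)(F)F`: 0.84 10^-6 cm/s

Compound 2 stands second highest of the three numbers in this assay; a 4.8-fold lower number from compound 1 to compound 2 (0.69 log units; beyond the scatter), and a 2.3-fold lower number from compound 2 to compound 3 (0.35 log units; beyond the scatter).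

Compound 4 `O=C(Nc1ccccn1)c1cccc(Oc2ccc3c(c2)c(=O)ncn3Cc2c(F)cc(F)cc2F)c1C(F)(F)F` is the next step from compound 2: pyridin-2-yl in place of hydrogen on an amide-type nitrogen. For the measured compounds named here, the step that bears on it is the one from compound 2 to compound 3, where a 2.3-fold lower number from compound 2 to compound 3 (0.35 log units; beyond the scatter); the step from compound 1 to compound 3 (an 11-fold lower number from compound 1 to compound 3 (1.04 log units; beyond the scatter)) shows the whole change from hydrogen to phenylcarbamoyl. A modest lowering of the same order is therefore expected for compound 4 in this assay, a 1.9-fold lower number from compound 2 to compound 4 (0.28 log units; within the scatter). Compound 4 is estimated at 1 10^-6 cm/s, range 0.45 10^-6 cm/s to 2.3 10^-6 cm/s.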

Compound 4, apparent permeability: 1.2 10^-6 cm/s
Compound 4: middle estimate off by 1.2-fold (0.08 log units), on the low side; the measured number falls inside the stated range.
By their numbers in this assay, from the lowest: compounds 3, 4 and 2 (each within the scatter of the next, the first and the last beyond it); then compound 1.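

Pyridin-2-yl on the amide-type nitrogen (a 1.6-fold lower number from compound 2 to compound 4 (0.20 log units; within the scatter)) leaves compound 4 unresolved from compound 2 in this assay, whereas the step to phenyl at this nitrogen was printed as beyond the scatter. Pyridin-2-yl in place of phenyl (a 1.4-fold higher number from compound 3 to compound 4 (0.15 log units; within the scatter)) also stays within the scatter, so the ring nitrogen produces no resolved difference here. The full (pyridin-2-yl)carbamoyl in place of hydrogen on the aromatic carbon still gives a clear drop (a 7.7-fold lower number from compound 1 to compound 4 (0.88 log units; beyond the scatter)).

Open, as far as these compounds go, is whether a carboxylic acid, an amine or a longer chain on this amide-type nitrogen would separate from compound 2. No available evidence accounts for these numbers.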